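Carbamate chain length and growth inhibition of selenocyanate anilides

The compounds below may be only part of what the source reports. "The series", "measured", "known", "first", "only" and "open" are said of these compounds alone.

Measured compounds:
Compound 1 `CCCCOC(=O)Nc1ccc([Se]C#N)cc1` gives 40800 nM in a functional assay on PC-3 cells (Homo sapiens) for cytotoxicity, read by MTT assay, with a stated time of 72 h; a higher number here means a weaker inhibitor of growth, a lower number a stronger inhibitor of growth.
Compound 2 `CC(C)COC(=O)Nc1ccc([Se]C#N)cc1` gives 47300 nM in this assay.
Compound 3 `C=CCOC(=O)Nc1ccc([Se]C#N)cc1` gives 44700 nM in this assay.

Compound 3 lies within the scatter of both of its neighbours: the step of a 1.1-fold higher number from compound 1 to compound 3 (0.04 log units; within the scatter) and the step of a 1.1-fold lower number from compound 2 to compound 3 (0.02 log units; within the scatter) are both within the scatter, as is a 1.2-fold higher number from compound 1 to compound 2 (0.06 log units; within the scatter). Across the three measured compounds the chain on the saturated chain carbon bound to an oxygen next to a carbonyl group has been varied without any change in this assay that rises beyond the scatter.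

Compound 4 `CCCCCCOC(=O)Nc1ccc([Se]C#N)cc1` differs from compound 3 by pentyl in place of vinyl on a saturated chain carbon bound to an oxygen next to a carbonyl group. All three measured steps bear on this change, since each also exchanges one chain for another at the same place, and each was within the scatter. The step in this assay is therefore expected to be none beyond the scatter, in no particular direction: a 1.1-fold lower number from compound 3 to compound 4 (0.03 log units; within the scatter). Compound 4 is estimated at 42000 nM, with a range from 21000 nM to 84000 nM in this assay.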

Compound 4, concentration for total growth inhibition: 44600 nM
Compound 4: middle estimate off by 1.1-fold (0.03 log units), on the low side, and the stated range covers the measured number.
By their numbers in this assay, from the lowest: compounds 1, 4, 3 and 2 (each within the scatter of the next).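

Taking pentyl in place of vinyl on a saturated chain carbon bound to an oxygen next to a carbonyl group removes the double bond and brings the group from 2 to 5 carbons, yet this assay shows a 1.0-fold lower number from compound 3 to compound 4 (0.00 log units; within the scatter). The earlier compounds shown here covered only shorter groups, and this longer unbranched chain also stays within the scatter of the branched one, with a 1.1-fold lower number from compound 2 to compound 4 (0.03 log units; within the scatter), and of the butyl carbamate, with a 1.1-fold higher number from compound 1 to compound 4 (0.04 log units; within the scatter). All four compounds therefore sit level at this position over the chains shown, and no measurement is available that would account for this.

On these data alone, it remains open whether a chain longer than hexyl, or a much shorter one such as methyl, would stay level with these four. The same holds for a phenyl ring, an amine or a carboxylic acid carried on the chain.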